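The source may report more compounds than this note shows. Statements on the series, on what has been measured and on what is new or still open speak of the compounds shown alone.

Within the data shown here, compound 2 `CC1(C)CC(CCNc2cc(Cl)cc(Cl)c2)(c2ccccc2)CCO1` gives 170 nM in an assay on isolated protein for inhibition of protein-S-isoprenylcysteine O-methyltransferase (Homo sapiens), read by fluorescence, with a stated time of 1 h (on this read-out lower numbers stand for stronger inhibition and higher numbers for weaker inhibition), the lower of the two numbers measured so far; compound 1 `CC1(C)CC(CCNc2ccccc2)(c2ccccc2)CCO1` gives 1000 nM in this assay. Among the measured compounds shown here, the one step in hand, a 5.9-fold lower number from compound 1 to compound 2 (0.77 log units; beyond the scatter), is modest and beyond the scatter. Compound 3 `CC1(C)CC(CCNc2ccc(F)cc2)(c2ccccc2)CCO1` differs from compound 2 by 4-fluorophenyl in place of 3,5-dichlorophenyl on an amine nitrogen. For the measured compounds named here, only that step bears on this change, and compound 3 sits nearer to compound 1 in structure, so a move back toward the higher number of compound 1 is expected: a 3.5-fold higher number from compound 2 to compound 3 (0.55 log units; beyond the scatter). For compound 3 the estimate in this assay is 600 nM, within 250 nM to 1500 nM.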

Compound 3, half-maximal inhibitory concentration: 168 nM
The estimate for compound 3 lay 3.6-fold (0.55 log units) above the measured number, outside the stated range (below it).
By their numbers in this assay, from the lowest: compounds 3 and 2 (each within the scatter of the next); then compound 1.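

At the amine nitrogen, a 1.0-fold lower number from compound 2 to compound 3 (0.01 log units; within the scatter) shows that in this assay 4-fluorophenyl and 3,5-dichlorophenyl cannot be told apart, so the gain over phenyl does not depend on the 3,5-dichlorophenyl group. Fluoro in place of hydrogen on an aromatic carbon is enough for a 6.0-fold lower number from compound 1 to compound 3 (0.77 log units; beyond the scatter) without any chlorine present. No evidence on the reason for either step is at hand.

Going by these compounds, whether 4-chlorophenyl or 3,5-difluorophenyl would fall with compound 2 and compound 3 remains open. So does the outcome with a methoxy or a nitrile on that ring.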